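From Chloro to Methyl on the Shared Core

The source may hold more compounds than are shown below. What is called first, only, known or untested is meant among the compounds shown, and "the series" means these compounds.

Of the compounds shown here, two with the same branched amino ether chain have been measured in an ADME assay on microsomes from liver (Mus musculus) for metabolic stability, read by LC-MS, using NADPH, with a stated time of 10 min, tested at 0.5 uM; on this read-out higher numbers stand for a more stable compound and lower numbers for a less stable compound. There, compound 1 (`COC(=O)Nc1cc(-c2cc(C)c(OC[C@@](C)(N)CC(C)C)cn2)ccn1`) gives 99%, while compound 2 (`Cc1cc(-c2cc(Cl)c(OC[C@@](C)(N)CC(C)C)cn2)ccn1`) gives 71%. Compound 2 therefore stands lower of the two, and the gap lies beyond the usual scatter.

Compound 3 (`Cc1cc(-c2cc(C)c(OC[C@@](C)(N)CC(C)C)cn2)ccn1`) has not yet been measured. It differs from compound 2 in one place: methyl in place of chloro on an aromatic carbon. This is methyl in place of chloro on an aromatic carbon, opposite the ring nitrogen. Compound 1 also carries methyl at that place, but it differs from compound 3 elsewhere, so its high reading cannot be assigned to the methyl. Within the data shown here, no measured pair isolates this exchange, which leaves the expectation loosely anchored and the range wide.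

The expected movement in this assay is small and upward, and it is not expected to exceed the scatter: a number 4 percentage points higher from compound 2 to compound 3 (within the scatter). For compound 3, the estimated value is 75%, with an expected range from 56% to 93%.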

Compound 3, percent of the compound remaining: 72%
Compound 3: the middle estimate sits 3 percentage points above what was measured; measured number inside the range.
By their numbers in this assay, from the lowest: compounds 2 and 3 (each within the scatter of the next); then compound 1.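

In this assay, the exchange on the aromatic carbon opposite the ring nitrogen is now isolated: methyl in place of chloro comes with a number 1 percentage points higher from compound 2 to compound 3 (within the scatter), so the two groups cannot be told apart at this position on this read-out. Compound 3 also isolates a second place, where methyl in place of (methoxycarbonyl)amino on an aromatic carbon comes with a number 27 percentage points lower from compound 1 to compound 3 (beyond the scatter), which ties the high reading of compound 1 to the (methoxycarbonyl)amino group and not to the methyl it shares with compound 3. Nothing available explains either step.

Whether the position opposite the ring nitrogen stays as indifferent with a fluoro, a methoxy or a longer chain such as ethyl remains open, since chloro and methyl are the only two groups shown there. Also open, on these data alone, is whether the reading of compound 1 depends on the whole (methoxycarbonyl)amino group, or whether a plain amine or an acetylamino group at that place, or chloro paired with the (methoxycarbonyl)amino group on the shared core, would read the same.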